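The source may hold more compounds than are shown below. What is called first, only, known or untested is meant among the compounds shown, and "the series" means these compounds.

Measured so far in a functional assay on HCT-116 cells (Homo sapiens) for antiproliferative activity, read by MTT assay, with a stated time of 48 h (on this read-out higher numbers stand for weaker inhibition and lower numbers for stronger inhibition), are
- compound 1 `CCCCCCCCC(CCO)n1cnc2c(N(C)C)ncnc21` with 19800 nM
- compound 2 `CCCCCCCCC(CCO)n1cnc2c(N)ncnc21` with 11600 nM

Within the data shown here, compound 1 and compound 2 stand within the scatter of each other, with a 1.7-fold lower number from compound 1 to compound 2 (0.23 log units; within the scatter) as the only measured step. Compound 3 `CCCCCCCCCCCC(CCO)n1cnc2c(N(C)C)ncnc21` differs from compound 1 by propyl in place of hydrogen on a saturated chain carbon, nine bonds along the chain from an aromatic nitrogen and keeps the shared core. Among the measured compounds shown here, the measured step concerns amino in place of dimethylamino on an aromatic carbon, not the chain, so no measured step bears directly on this change. The forecast in this assay is therefore a judgement, a moderate move to a lower number. The expected step is a 2.5-fold lower number from compound 1 to compound 3 (0.39 log units; beyond the scatter) and it is uncertain. For compound 3 the estimated value is 8000 nM with an expected range from 2500 nM to 25000 nM as a wide allowance.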

Compound 3, half-maximal inhibitory concentration: 12000 nM
Compound 3: the middle estimate sits 1.5-fold (0.18 log units) below what was measured; measured number inside the range.
By their numbers in this assay, from the lowest: compounds 2, 3 and 1 (each within the scatter of the next).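

On the saturated chain carbon, nine bonds along the chain from an aromatic nitrogen, propyl in place of hydrogen gives a 1.7-fold lower number from compound 1 to compound 3 (0.22 log units; within the scatter) in this assay. The chain position thus tolerates this added propyl with no change distinguishable from scatter, whereas the earlier pair addressed only amino against dimethylamino on the aromatic carbon. Nothing available accounts for this result.

Still open, from the compounds shown here alone, is whether a much longer chain at this place would separate from compound 1 beyond the scatter. Also open, going by these compounds, is how a carboxylic acid or an amine at the chain end would read.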